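Fluoro in place of methoxy: an estimate for compound 3

This account rests on a few compounds, and the source may have more. Where it says the series, first, only, none or still open, it means among the compounds named here.

Compound 1 `Cc1nc(NC(C2CC2)C2CC2)c2nc(C)n(-c3ccc(OC(F)F)cc3Cl)c2n1`: 0.373 nM
Compound 2 `COc1cc(OC(F)F)ccc1-n1c(C)nc2c(NC(C3CC3)C3CC3)nc(C)nc21`: 0.291 nM

In a functional assay on CHO cells for antagonist activity at corticotropin-releasing factor receptor 1 (Homo sapiens), read by cAMP accumulation (a lower number here means a stronger inhibitor, a higher number a weaker inhibitor), compound 2 gives 0.291 nM, the lowest of the two numbers, while compound 1 gives 0.373 nM; the step of a 1.3-fold lower number from compound 1 to compound 2 (0.11 log units; within the scatter) lies within the scatter. Compound 3 `Cc1nc(NC(C2CC2)C2CC2)c2nc(C)n(-c3ccc(OC(F)F)cc3F)c2n1` differs from compound 2 by fluoro in place of methoxy on an aromatic carbon. Within the data shown here, the one measured step that bears on this, a 1.3-fold lower number from compound 1 to compound 2 (0.11 log units; within the scatter), is also an exchange on that aromatic carbon and changed little. Compound 3 is therefore expected to show a step of a 1.4-fold higher number from compound 2 to compound 3 (0.14 log units; within the scatter) that stays within the scatter. Compound 3 is estimated at 0.4 nM, within 0.15 nM to 1.1 nM.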

Compound 3, inhibition constant: 7 nM
Compound 3: middle estimate off by 18-fold (1.24 log units), on the low side; the measured number lies above the stated range.
By their numbers in this assay, from the lowest: compounds 2 and 1 (each within the scatter of the next); then compound 3.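

On the aromatic carbon ortho to a large group, the substituent matters in this assay after all: fluoro gives a 24-fold higher number from compound 2 to compound 3 (1.38 log units; beyond the scatter) and a 19-fold higher number from compound 1 to compound 3 (1.27 log units; beyond the scatter) while chloro and methoxy stay within the scatter of each other. The earlier exchange had suggested that this carbon accepted change freely, but that holds only for those two groups. Going by these compounds, whether a methyl or a bromo here would read like chloro and methoxy or like fluoro stays open, as does whether the loss would persist with an ethoxy in place of the difluoromethoxy group. Nothing given here accounts for the gap.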